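The compounds below may be only part of what the source reports. "The series", "measured", "known", "first", "only" and "open" are said of these compounds alone.

Two compounds share one core and differ in a single group on a six-membered aromatic ring of carbon only. Compound 1 `Cc1ccc([C@H]2CC(c3ccccc3)=NN2c2ncc(Br)cn2)cc1` carries a methyl there, and in a functional assay on the whole organism (strain Wistar albino) for inhibition, with Rattus norvegicus as the target, read by paw edema, with stated times of 30 min and 2.5 h, at a dose of 20 mg/kg (a lower number here means less inhibition, a higher number more inhibition at the dose given (going by the name of the read-out)), compound 1 gives 72%. Compound 2 `Clc1ccc([C@H]2CC(c3ccccc3)=NN2c2ncc(Br)cn2)cc1` carries a chloro at that same place, and in this assay compound 2 gives 72%. For the measured compounds named here, the one step measured so far, no change at the digits printed from compound 1 to compound 2 (within the scatter), shows that exchanging these two groups left the read-out where it was. Compound 2 therefore stands level with compound 1 on the numbers in hand, with nothing to separate the two. Compound 3 `Brc1ccc([C@H]2CC(c3ccccc3)=NN2c2ncc(Br)cn2)cc1` differs from compound 2 by bromo in place of chloro on an aromatic carbon. Going by the values given here, the only step that bears on this is the flat one from compound 1 to compound 2, and a further exchange of one halogen for another at the same place gives no reason to expect a different outcome. The step from compound 2 to compound 3 is therefore expected to be no change at the digits printed from compound 2 to compound 3 (within the scatter), nothing beyond the scatter. Compound 3 is thus estimated to give 72% in this assay, within a range from 62% to 82%.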

Compound 3, a percentage reported as inhibition, in the whole organism at one dose (the size of the read-out at that dose, not a potency): 78%
Compound 3: middle estimate off by 6 percentage points, on the low side; the range from low to high includes it.
By their numbers in this assay, from the lowest: compounds 1, 2 and 3 (each within the scatter of the next).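

In this assay, the exchange of chloro for bromo on an aromatic carbon of this six-membered ring gives a number 6 percentage points higher from compound 2 to compound 3 (within the scatter) and the exchange of methyl for bromo gives a number 6 percentage points higher from compound 1 to compound 3 (within the scatter) so neither step separates the compounds. With three groups now read at this place, para to a large group, methyl, chloro and bromo all give values within the scatter of one another, and the flat result seen with the first pair now extends to a second halogen and holds for every pair among these three compounds. No evidence is available that explains this outcome.

The compounds shown leave open whether this position stays as undemanding with groups of a quite different kind, such as an amine, a carboxylic acid or a longer chain like butyl, since all three groups here leave the read-out within the scatter and so do not reveal what would move it. They also leave open how these compounds compare in potency, as a read-out at a single dose gives the size of the effect at that dose and not a potency.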